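The compounds below may be only part of what the source reports. "The series", "measured", "known", "first", "only" and "open" are said of these compounds alone.

Compound 1 `Nc1nc(=O)ccn1[C@@H]1O[C@H](COP(=O)(O)O)[C@@H](O)[C@H]1O` is the starting point. In an in vitro functional assay on 1321-N1 cells for agonist activity at P2Y purinoceptor 6 (Homo sapiens), read by scintillation proximity assay and inositol phosphate accumulation (a higher number here means that more compound is needed for the effect, a lower number that less compound is needed), compound 1 gives > 100000 nM, which is a limit of the assay and not a number. Compound 1 thus sits at the limit of > 100000 nM in this assay, at which 1 of the 3 values shown sits, and cannot be ranked against the others by a measured value. Two further compounds, built differently elsewhere on the core, give numbers or limits of their own. Compound 2 `COc1nc(=O)ccn1[C@@H]1O[C@H](COP(=O)(O)OP(=O)(O)O)[C@@H](O)[C@H]1O` gives 1370 nM in this assay. Compound 3 `CCCSc1nc(=O)ccn1[C@@H]1O[C@H](COP(=O)(O)OP(=O)(O)O)[C@@H](O)[C@H]1O` gives >= 100000 nM in this assay, which is a limit of the assay. Among the measured compounds shown here, the one measured step, an at least 72-fold higher number from compound 2 to compound 3 (1.86 log units; beyond the scatter), concerns a substituent on an aromatic carbon in that pair and does not bear directly on the change made to compound 1. Compound 4 `CNc1nc(=O)ccn1[C@@H]1O[C@H](COP(=O)(O)O)[C@@H](O)[C@H]1O` differs from compound 1 by methyl in place of hydrogen on a nitrogen on an aromatic ring. For the measured compounds named here, no measured step shows the effect of this change. With compound 1 already at a limit, compound 4 is expected to remain there, with an estimated 100000 nM (range 30000 nM to 300000 nM), a step of a number no higher from compound 1 to compound 4 (the limit leaves the size open) that is expected to be none beyond the scatter.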

Compound 4, half-maximal effective concentration: > 100000 nM
Compound 4 gave a limit, no number (the forecaster's own chance of this, stated with the estimate: 85%); the middle value sits exactly at the limit.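

No step can be read from compound 1 to compound 4, since each gives only a limit and no number in this assay: the limit of > 100000 nM in this assay, at which 2 of the 4 values shown sit.

The compounds shown leave open whether methyl in place of hydrogen on a nitrogen on an aromatic ring shifts the number at all.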